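From compound 3 to compound 4: adding a trifluoromethyl

The compounds below may be only part of what the source reports. "The series", "measured", "known", "first", "only" and "open" are said of these compounds alone.

In an ADME assay on MDCK cells (Canis lupus familiaris) for cytotoxicity (a higher number here means that more compound is tolerated, a lower number that less compound is tolerated), compound 3 (`O=[N+]([O-])C1=NNc2ncnn2C1c1ccc(O)c(O)c1O`) gives 228000 nM as its reading. That value lies within the usual scatter of compound 1 (`O=[N+]([O-])C1=NNc2nc(C(F)(F)F)nn2C1c1ccc(O)c(O)c1`) at 183000 nM on the same scale, while compound 2 (`O=[N+]([O-])C1=NNc2nc(C(F)(F)F)nn2C1c1ccc(O)cc1O`) at 108000 nM on that scale lies lower, beyond the scatter.

Compound 4 (`O=[N+]([O-])C1=NNc2nc(C(F)(F)F)nn2C1c1ccc(O)c(O)c1O`) differs from compound 3 by one change, trifluoromethyl in place of hydrogen on an aromatic carbon. Going by the values given here, no measured step tests this swap directly. Among the compounds with values here, the only measured step is a 1.7-fold lower number from compound 1 to compound 2 (0.23 log units; within the scatter) and it exchanges 3,4-dihydroxyphenyl for 2,4-dihydroxyphenyl, so it offers only a sense of how little these numbers have moved. More useful is that compound 1 carries the trifluoromethyl and reads 183000 nM within the scatter of compound 3.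

The step expected in this assay therefore stays within the scatter, estimated as a 1.4-fold lower number from compound 3 to compound 4 (0.15 log units; within the scatter) and leaning slightly lower. For compound 4 the estimate is 160000 nM with an expected range from 80000 nM to 320000 nM in this measurement.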

Compound 4, half-maximal cytotoxic concentration: 67000 nM
Estimate against measurement, compound 4: 2.4-fold (0.38 log units) above, and the stated range ends above it.
By their numbers in this assay, from the lowest: compounds 4, 2, 1 and 3 (each within the scatter of the next, the first and the last beyond it).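

In this assay, going by these compounds alone, the step of a 3.4-fold lower number from compound 3 to compound 4 (0.53 log units; beyond the scatter) gives the first direct reading at this position, on an aromatic carbon between two ring nitrogen atoms: with the rest of the molecule unchanged, trifluoromethyl in place of hydrogen means modestly less compound is tolerated. The phenyl ring adds a second point, as hydroxy in place of hydrogen on an aromatic carbon gives a 2.7-fold lower number from compound 1 to compound 4 (0.44 log units; beyond the scatter) but only a 1.6-fold lower number from compound 2 to compound 4 (0.21 log units; within the scatter), so the same kind of swap goes beyond the scatter in one pair and stays within it in the other. Nothing measured here offers a reason for either result.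

Going by these compounds, whether a methyl or an amine on the same carbon would also lower the number remains open. So does whether trifluoromethyl would give a step of similar size alongside the 3,4-dihydroxyphenyl or 2,4-dihydroxyphenyl group.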